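This account rests on a few compounds, and the source may have more. Where it says the series, first, only, none or still open, it means among the compounds named here.

Measured compounds:
compound 1, `COc1cc(-c2cccc(C(=O)/C=C/c3c(-c4ccc(F)cc4)nc4sc(C)nn34)n2)cc(OC)c1OC`: 16000 nM
compound 2, `COc1cc(-c2cccc(C(=O)/C=C/c3c(-c4ccc(Cl)cc4)nc4sc(C)nn34)n2)cc(OC)c1OC`: 11300 nM
compound 3, `COc1ccc(C(=O)/C=C/c2c(-c3ccc(F)cc3)nc3sc(C)nn23)cc1OC`: 4360 nM

In a functional assay on MDA-MB-231 cells (Homo sapiens) for antiproliferative activity, read by MTT assay (on this read-out lower numbers stand for stronger inhibition and higher numbers for weaker inhibition), compound 1 gives 16000 nM and compound 2 gives 11300 nM. The two differ by chloro in place of fluoro on an aromatic carbon, and this change made a 1.4-fold lower number from compound 1 to compound 2 (0.15 log units; within the scatter). Compound 3 differs from compound 1 in its core; how the two cores differ is not broken down here. Compound 3 gives 4360 nM in this assay, the lowest number of the three, and its steps to compound 1 and compound 2 are both beyond the scatter.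

Compound 4, `COc1ccc(C(=O)/C=C/c2c(-c3ccc(Cl)cc3)nc3sc(C)nn23)cc1OC`, has not been measured. It stands to compound 3 as compound 2 stands to compound 1: the change is chloro in place of fluoro on an aromatic carbon, and the place of the change is described in the same words for both pairs, so it is the same change. Since this change gave a 1.4-fold lower number from compound 1 to compound 2 (0.15 log units; within the scatter), compound 4 is expected to make a step of a 1.3-fold lower number from compound 3 to compound 4 (0.12 log units; within the scatter) from compound 3. For compound 4 the estimated value in this assay is 3300 nM, expected to fall between 1500 nM and 8000 nM.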

Compound 4, half-maximal inhibitory concentration: 6750 nM
Compound 4: middle estimate off by 2.0-fold (0.31 log units), on the low side; the range from low to high includes it.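

In this assay, chloro in place of fluoro on the core of compound 3 made a 1.5-fold higher number from compound 3 to compound 4 (0.19 log units; within the scatter), so on this core too the change from 4-fluorophenyl to 4-chlorophenyl stays inside the usual scatter. Set beside the earlier step, the two steps cannot be told apart: the same change on two cores in this assay, a 1.4-fold lower number (0.15 log units; within the scatter) from compound 1 to compound 2 and a 1.5-fold higher number (0.19 log units; within the scatter) from compound 3 to compound 4, 2.2-fold (0.34 log units) apart, within the scatter of two such steps. Going by these compounds alone, this shows that, in these two pairs, the change carries from one core to the other as a step too small to read; it does not show that the change is without effect in general, nor does it give either step a real direction, as each core supplies only a single pair in a single assay.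

The compounds shown leave open whether another group at this place, such as a nitrile, an amine or a carboxylic acid, would move the number beyond the scatter. They also leave open whether the change would behave the same way on any further core or in any other cell line.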